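This account rests on a few compounds, and the source may have more. Where it says the series, first, only, none or still open, it means among the compounds named here.

The measured compounds:
compound 1 `COc1ccc(-c2nn(-c3ccccc3)cc2/C=C/C(=O)c2ccc(OCc3ccccc3)c3c2OC(C)(C)C3)cc1`; in a functional assay on PC-3 cells (Homo sapiens) for antiproliferative activity, read by MTT assay, with a stated time of 48 h (a lower number here means a stronger inhibitor, a higher number a weaker inhibitor), compound 1 gives 7900 nM.
compound 2 `CC1(C)Cc2c(ccc(C(=O)/C=C/c3cn(-c4ccccc4)nc3-c3ccccc3)c2OCc2ccccc2)O1`; in this assay compound 2 gives > 100000 nM, which is a limit of the assay and not a number.

Compound 2 therefore has no exact place on the scale: all that is known is the limit of > 100000 nM in this assay, at which 1 of the 2 values shown sits. For the measured compounds named here, compound 1 and compound 2 differ in more than one place, so their two values show only that compound 1 returned a number while compound 2 did not.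

Compound 3 `CC1(C)Cc2c(ccc(C(=O)/C=C/c3cn(-c4ccccc4)nc3-c3ccc([N+](=O)[O-])cc3)c2OCc2ccccc2)O1` differs from compound 2 by one change, (nitro in place of hydrogen on an aromatic carbon), that is, nitro in place of hydrogen on an aromatic carbon. Going by the values given here, no step between two measured compounds is available to calibrate this change, so the expected direction rests on little. With compound 2 sitting at a limit, a step toward stronger inhibition can only be guessed at, and there is a real chance that compound 3 also returns only a limit. The expected step from compound 2 to compound 3 is an at least 2.5-fold lower number from compound 2 to compound 3 (0.39 log units; beyond the scatter). Compound 3 is estimated at 40000 nM, with a range from 8000 nM to 150000 nM.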

Compound 3, half-maximal inhibitory concentration: 62300 nM
Estimate against measurement, compound 3: 1.6-fold (0.19 log units) below, within the range that was stated.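

In this assay compound 3 gives 62300 nM, so the change from phenyl to 4-nitrophenyl, made on an aromatic carbon of a six-membered ring, yields a real number where the unsubstituted compound gave none. This is also the only single change shown so far, and it reads as an at least 1.6-fold lower number from compound 2 to compound 3 (0.20 log units; that floor lies within the scatter); the true step may be larger, but the figure alone does not place it beyond ordinary repeat-to-repeat variation. The step has only a floor and no exact size because compound 2 is known only through a limit, not a number: the limit of > 100000 nM in this assay, at which 1 of the 3 values shown sits.

One substituent at one position cannot show whether the nitro group itself matters or whether other groups at this carbon would give similar numbers. An amine or a carboxylic acid in the same place would test this, and the same change on a compound with a measurable starting value would give a step of exact size.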